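Cyclohexylamino Addition to Compound 1: Expected Cytotoxicity

The source may hold more compounds than are shown below. What is called first, only, known or untested is meant among the compounds shown, and "the series" means these compounds.

Measured compounds:
compound 1, `N=C(Nc1cccc(C(F)(F)F)c1)c1cc2c(-c3ccccc3)n[nH]c2cn1`, 22300 nM
compound 2, `Cn1nc(-c2ccccc2)c2cc(C(=N)Nc3cccc(C(F)(F)F)c3)ncc21`, 21400 nM
compound 3, `N=C(Nc1ccccc1)c1cc2c(-c3ccccc3)n[nH]c2cn1`, 11000 nM

In a functional assay on MDA-MB-231 cells (Homo sapiens) for cytotoxicity, read by MTT assay, with a stated time of 72 h (on this read-out lower numbers stand for stronger inhibition and higher numbers for weaker inhibition), compound 1 gives 22300 nM, the highest of the three numbers. Compound 2 sits within the scatter of it, as a 1.0-fold lower number from compound 1 to compound 2 (0.02 log units; within the scatter) shows, so the two cannot be ordered. Compound 3 gives the lowest number, and a 2.0-fold lower number from compound 1 to compound 3 (0.31 log units; beyond the scatter) is a modest step that lies beyond the scatter.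

Compound 4 is `N=C(Nc1cccc(C(F)(F)F)c1)c1cc2c(-c3ccccc3)n[nH]c2c(NC2CCCCC2)n1`. The change from compound 1 is cyclohexylamino in place of hydrogen on an aromatic carbon. Neither measured step touches this part of the shared core: the step from compound 1 to compound 2 concerns the aromatic nitrogen, the step from compound 1 to compound 3 the trifluoromethyl on the aniline ring, and both are small. Within the data shown here, there is therefore no measured step that bears on the cyclohexylamino addition, and no direction can be read from the series. The expectation for compound 4 in this assay is a number close to that of compound 1, with a wide range, expressed as a 1.5-fold lower number from compound 1 to compound 4 (0.17 log units; within the scatter). The estimated value for compound 4 is 15000 nM, between 4000 nM and 60000 nM.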

Compound 4, half-maximal inhibitory concentration: 24600 nM
Compound 4: middle estimate off by 1.6-fold (0.21 log units), on the low side, within the range that was stated.
By their numbers in this assay, from the lowest: compounds 3, 2, 1 and 4 (each within the scatter of the next, the first and the last beyond it).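

Cyclohexylamino in place of hydrogen gives a 1.1-fold higher number from compound 1 to compound 4 (0.04 log units; within the scatter) in this assay, so this exchange on the aromatic carbon next to the ring nitrogen leaves no readable change in the number. Among these compounds, the earlier steps covered only the aromatic nitrogen and the trifluoromethyl on the aniline ring, whereas this result adds a first reading at this position and shows that an entering group of 7 heavy atoms, with its six-membered non-aromatic ring of carbon, can stand here without a shift beyond the scatter. No measurement accompanying the series accounts for this flat step.

The single substituent leaves open whether the position stays flat across other groups, such as a simple methylamino group, an open-chain pentylamino group, a morpholine or a carboxylic acid on the same carbon. The compounds shown also leave open whether cyclohexylamino gives the same result when the aniline ring lacks trifluoromethyl or when the aromatic nitrogen carries methyl, since the addition is seen only on the core of compound 1.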